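Dichlorination of the Pyridyl Arm in a Small Series

The compounds below may be only part of what the source reports. "The series", "measured", "known", "first", "only" and "open" are said of these compounds alone.

The study began from compound 1 `CCOC(=O)c1cnc(C(F)(F)F)nc1NN1C(=O)C=C(C)C1=O` and compound 2 `CCOC(=O)c1cnc(-c2ccncc2)nc1NN1C(=O)C=C(C)C1=O`. In a functional assay on Jurkat cells for inhibition of nuclear factor NF-kappa-B complex (Homo sapiens) (a higher number here means a weaker inhibitor, a lower number a stronger inhibitor), compound 1 gave 1000 nM, while compound 2 gave 6000 nM, the higher of the two numbers shown; the step of a 6.0-fold higher number from compound 1 to compound 2 (0.78 log units; beyond the scatter) set compound 2 apart from compound 1. The unmeasured compound 3 `CCOC(=O)c1cnc(-c2cc(Cl)nc(Cl)c2)nc1NN1C(=O)C=C(C)C1=O` differs from compound 2 by a single change, (2,6-dichloropyridin-4-yl in place of pyridin-4-yl on an aromatic carbon). Among the measured compounds shown here, no measured pair in this set shares that change, so the one step known, from compound 1 to compound 2, speaks only to the exchange of trifluoromethyl for pyridin-4-yl and not to chlorine on that pyridyl ring. With nothing directly comparable, the account expects compound 3 to stay in the same region as compound 2, with a step of a 1.2-fold lower number from compound 2 to compound 3 (0.08 log units; within the scatter) not clearly beyond the scatter. The estimate for compound 3 in this assay is 5000 nM, within a range from 1500 nM to 15000 nM.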

Compound 3, half-maximal inhibitory concentration: 2000 nM
The estimate for compound 3 lay 2.5-fold (0.40 log units) above the measured number; the range from low to high includes it.
By their numbers in this assay, from the lowest: compounds 1 and 3 (each within the scatter of the next); then compound 2.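

In this assay the two chlorines on the pyridyl arm produced a 3.0-fold lower number from compound 2 to compound 3 (0.48 log units; beyond the scatter), the first sign that this position, between two ring nitrogen atoms, responds to substitution on the pyridyl ring itself and not only to the exchange of one whole group for another. The step of a 2.0-fold higher number from compound 1 to compound 3 (0.30 log units; within the scatter) leaves 2,6-dichloropyridin-4-yl and trifluoromethyl indistinguishable at this position, so a pyridyl arm need not stand apart from trifluoromethyl as the pyridin-4-yl of compound 2 does. Nothing available gives a reason for either step.

The compounds shown leave open whether a single chlorine would serve as well as two, and whether the effect is particular to chlorine. Methyl groups, methoxy groups or an amine on the same pyridyl ring would address that question.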